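This account rests on a few compounds, and the source may have more. Where it says the series, first, only, none or still open, it means among the compounds named here.

Measured in a functional assay on PC-3 cells (Homo sapiens) for antiproliferative activity, read by sulforhodamine B assay; a lower number here means a stronger inhibitor of growth, a higher number a weaker inhibitor of growth:

Compound 1 `CC(C)CCCOc1cccc(O)c1C(=O)/C=C/c1ccc(O)cc1`: 3600 nM.
Compound 2 `CCCCCCOc1cccc(O)c1C(=O)/C=C/c1ccc(O)cc1`: > 30000 nM, a limit.
Compound 3 `CCCCOc1cccc(O)c1C(=O)/C=C/c1ccc(O)cc1`: > 30000 nM, a limit.

Compound 3 has no exact number, only the limit > 30000 nM. It sits at the limit of > 30000 nM in this assay, at which 2 of the 3 values shown sit, and compound 2 is the other compound there.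

The unmeasured compound 4 `O=C(/C=C/c1ccc(O)cc1)c1c(O)cccc1OCCC1CCCC1` differs from compound 3 by one change: cyclopentyl in place of ethyl on a saturated chain carbon, two bonds along the chain from an oxygen on an aromatic ring. Cut one bond further out, this reads butoxy to 2-cyclopentylethoxy.

Among the measured compounds shown here, no measured step makes this same change, so the evidence is indirect. The closest steps are an at least 8.3-fold higher number from compound 1 to compound 3 (0.92 log units; beyond the scatter) and an at least 8.3-fold higher number from compound 1 to compound 2 (0.92 log units; beyond the scatter). In each, the isopropyl of compound 1 gives way to a smaller unbranched end, and the number rises beyond the scatter. The third step, a step that the two limits leave unreadable from compound 2 to compound 3, adds nothing. Among these three compounds, only compound 1 gives a number, at 3600 nM, and its chain ends in a branched group, as the chain of compound 4 does. A lower number than that of compound 3 is therefore expected, of a size similar to those two steps, though compound 4 may also stay at the limit.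

The expected change is an at least 5.0-fold lower number from compound 3 to compound 4 (0.69 log units; beyond the scatter). For compound 4 the estimated value is 6000 nM, with an expected range of 1500 nM to 30000 nM.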

Compound 4, concentration for 50% growth inhibition: 3480 nM
The estimate for compound 4 lay 1.7-fold (0.24 log units) above the measured number; the range from low to high includes it.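

In this assay, cyclopentyl on the saturated chain carbon, two bonds along the chain from an oxygen on an aromatic ring, gives a readable number where the smaller ethyl does not, with an at least 8.6-fold lower number from compound 3 to compound 4 (0.93 log units; beyond the scatter) and, against the other unbranched chain, an at least 8.6-fold lower number from compound 2 to compound 4 (0.93 log units; beyond the scatter). Compound 4 is also level with the branched chain of compound 1, at a 1.0-fold lower number from compound 1 to compound 4 (0.01 log units; within the scatter), so among the compounds shown, a readable number goes with a chain that ends in a branch or a ring, and the isobutyl and cyclopentyl forms cannot be told apart here. The unbranched compound 2 and compound 3 remain limits of the assay rather than numbers, so no order between them can be read: the limit of > 30000 nM in this assay, at which 2 of the 4 values shown sit.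

The compounds shown leave open whether a larger ring such as cyclohexyl, or a cyclopentyl set on a shorter or longer link to the oxygen, would hold, lower or lose this number. They also leave open whether an amine or a carboxylic acid at the end of the chain would be tolerated at this position.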